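The source may report more compounds than this note shows. Statements on the series, on what has been measured and on what is new or still open speak of the compounds shown alone.

Measured in a functional assay on MGC-803 cells (Homo sapiens) for inhibition, read by sulforhodamine B assay; on this read-out lower numbers stand for stronger inhibition and higher numbers for weaker inhibition:
- Compound 1 `Cc1ccc(NC2=CC(=O)c3c(nc4n3[C@H]3OC[C@@H](O)[C@H]3OC4)C2=O)cc1`: 1550 nM
- Compound 2 `COc1ccccc1NC1=CC(=O)c2c(nc3n2[C@H]2OC[C@@H](O)[C@H]2OC3)C1=O`: 1670 nM
- Compound 3 `O=C1C(NC2CCCCC2)=CC(=O)c2c1nc1n2[C@H]2OC[C@@H](O)[C@H]2OC1`: > 8000 nM, a limit and not a number

Compound 3 stands at the limit of > 8000 nM in this assay, at which 1 of the 3 values shown sits. Compound 4 `O=C1C(Nc2cccc(F)c2)=CC(=O)c2c1nc1n2[C@H]2OC[C@@H](O)[C@H]2OC1` carries 3-fluorophenyl in place of cyclohexyl on an amine nitrogen. For the measured compounds named here, two measured steps bear on this, running the opposite way by putting cyclohexyl in place of a substituted phenyl: an at least 5.1-fold higher number from compound 1 to compound 3 (0.71 log units; beyond the scatter) and an at least 4.7-fold higher number from compound 2 to compound 3 (0.68 log units; beyond the scatter), both beyond the scatter. Changing one substituted phenyl for another gave a 1.1-fold higher number from compound 1 to compound 2 (0.03 log units; within the scatter), within the scatter. A clear fall in the number, meaning stronger inhibition, is therefore expected, and the estimated step is an at least 4.4-fold lower number from compound 3 to compound 4 (0.64 log units; beyond the scatter). For compound 4 the expected value is 1800 nM, with an estimated range of 700 nM to 4500 nM.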

Compound 4, half-maximal inhibitory concentration: 1470 nM
Compound 4: middle estimate off by 1.2-fold (0.09 log units), on the high side, within the range that was stated.
By their numbers in this assay, from the lowest: compounds 4, 1 and 2 (each within the scatter of the next). At a limit, above all of these: compound 3.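

Moving from a saturated ring to a substituted phenyl on this amine nitrogen now holds in a third compound, with 3-fluorophenyl in place of cyclohexyl (an at least 5.4-fold lower number from compound 3 to compound 4 (0.73 log units; beyond the scatter)). Compound 4 also matches the other two substituted phenyl compounds (a 1.1-fold lower number from compound 2 to compound 4 (0.06 log units; within the scatter); a 1.1-fold lower number from compound 1 to compound 4 (0.02 log units; within the scatter)), so 3-fluorophenyl, 2-methoxyphenyl and 4-methylphenyl cannot be told apart here. Compound 3 gives a limit and not a number, so the first step is only a minimum: (the limit of > 8000 nM in this assay, at which 1 of the 4 values shown sits).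

From the compounds shown here alone, how a pyridine ring, a benzyl group or a straight alkyl chain on this nitrogen would compare remains open.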